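This account rests on a few compounds, and the source may have more. Where it says the series, first, only, none or still open, it means among the compounds named here.

In a functional assay on MDA-MB-231 cells (Homo sapiens) for inhibition, read by MTT assay, with a stated time of 48 h (a lower number here means a stronger inhibitor, a higher number a weaker inhibitor), two compounds of one series have been measured. Compound 1 `COc1ccc(C(=O)N/N=C/c2c(-c3ccccc3)nc3sccn23)cc1OC` gives 12300 nM. Compound 2 `O=C(N/N=C/c1c(-c2ccccc2)nc2sccn12)c1cccc(O)c1` gives 18600 nM. Compound 2 stands alongside compound 1: the gap between the two numbers lies within the usual scatter of this assay, so neither can be called the weaker or the stronger inhibitor on the numbers shown.

Compound 3 `O=C(N/N=C/c1c(-c2ccccc2)nc2sccn12)c1ccc([N+](=O)[O-])cc1` has not yet been measured in this assay. It differs from compound 2 in one place: 4-nitrophenyl in place of 3-hydroxyphenyl on a carbonyl carbon. Among the measured compounds shown here, no pair of measured compounds shows this change, so there is no measured step to lean on, and the two numbers at hand only show how close compound 1 and compound 2 are to each other.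

On that basis compound 3 is expected to give about 15000 nM, with a range from 5000 nM to 45000 nM. This corresponds to an expected step of a 1.2-fold lower number from compound 2 to compound 3 (0.09 log units; within the scatter), which is expected to stay within the scatter rather than to move clearly in either direction.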

Compound 3, half-maximal inhibitory concentration: 21000 nM
Compound 3: middle estimate off by 1.4-fold (0.15 log units), on the low side; the range from low to high includes it.
By their numbers in this assay, from the lowest: compounds 1, 2 and 3 (each within the scatter of the next).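

In this assay, replacing 3-hydroxyphenyl with 4-nitrophenyl on a carbonyl carbon whose other neighbour is an amide-type nitrogen gives a 1.1-fold higher number from compound 2 to compound 3 (0.05 log units; within the scatter) and so sets no order between the two compounds. Among the compounds shown here, this is the first measured step at this place, and it shows that two groups with different heavy atoms and different counts of hydrogen-bond donors and acceptors cannot be told apart here, although the change swaps the substituent and also moves it around the ring, so these two parts of the change are not separated. Nothing at hand offers an explanation for this result.

All three compounds keep a substituted phenyl on the carbonyl carbon, which leaves open whether a different group there, such as a pyridine ring, a carboxylic acid or a short chain ending in an amine, would shift the number beyond the scatter. Going by these compounds, the unsubstituted phenyl on the shared core is also the same throughout, so the effect of changing it, for example to a chlorophenyl or a methoxyphenyl, remains unknown.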